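The source may hold more compounds than are shown below. What is called first, only, known or untested is meant among the compounds shown, and "the series" means these compounds.

Of the compounds shown here, two have so far been tested in a functional assay on CEM-DNR-bulk cells (Homo sapiens), read by MTT assay, with a stated time of 72 h; on this read-out lower numbers stand for stronger inhibition and higher numbers for weaker inhibition. Here compound 1 (`C#Cc1cn([C@@H]2O[C@H](CO)[C@@H](O)[C@H]2O)c2ncnc(NC)c12`) gives 18500 nM. Compound 2 (`CN(C)c1ncnc2c1c(-c1ccsc1)cn2[C@@H]1O[C@H](CO)[C@@H](O)[C@H]1O`) is reported as > 20000 nM, which is a limit of the assay and not a number. This leaves (the limit of > 20000 nM in this assay, at which 1 of the 2 values shown sits), so compound 2 has no exact position on the scale.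

Compound 3 (`C#Cc1cn([C@@H]2O[C@H](CO)[C@@H](O)[C@H]2O)c2ncnc(N(C)C)c12`) differs from compound 2 in one place, with ethynyl in place of thiophen-3-yl on an aromatic carbon of a five-membered aromatic ring with 1 nitrogen: ethynyl in place of thiophen-3-yl on an aromatic carbon. Among the compounds with values here, no measured pair of compounds shows what this swap does, so any expectation must lean on the single number available. Compound 1 also carries ethynyl and gives 18500 nM, so weak inhibition is expected for compound 3 as well. In this assay, the expected change is none beyond the usual scatter of repeated measurements, and the estimated step is a number no higher from compound 2 to compound 3 (the limit leaves the size open). A reading reported only as a limit would be no surprise. For compound 3 the estimated value is 20000 nM, with an expected range from 7000 nM to 40000 nM.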

Compound 3, half-maximal inhibitory concentration: 240 nM
Beside the measured number, compound 3's estimate is 83-fold (1.92 log units) above it; measured number outside the range, below it.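

In this assay ethynyl in place of thiophen-3-yl on an aromatic carbon gives an at least 83-fold lower number from compound 2 to compound 3 (1.92 log units; beyond the scatter) and so shows that the group at this place can move the reading far beyond the scatter. Compound 2 is reported only as a limit of the assay and not as a number, so this step has a minimum size and no exact one: the limit of > 20000 nM in this assay, at which 1 of the 3 values shown sits.

Ethynyl alone does not carry the result either: compound 1 has it too, and methyl in place of hydrogen on a nitrogen on an aromatic ring gives a 77-fold lower number from compound 1 to compound 3 (1.89 log units; beyond the scatter) as a second large step, so among the three compounds shown only the one with both ethynyl and this extra methyl reaches a low number.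

From the compounds shown here alone, only thiophen-3-yl and ethynyl appear at this carbon, so it remains open whether a nitrile, a small ring such as cyclopropyl or a longer chain such as prop-1-ynyl would keep the number low. Going by these compounds, on the nitrogen it is equally open how an ethyl group in place of a methyl would read, and nothing here explains why either step is so large.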